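The compounds below may be only part of what the source reports. "The series", "measured", "known", "first", "only" and "open" are said of these compounds alone.

Measured in a functional assay on A549 cells (Homo sapiens) for antiproliferative activity, read by MTT assay, with a stated time of 48 h; a higher number here means a weaker inhibitor, a lower number a stronger inhibitor:
Compound 1 `C#Cc1cccc(Nc2ncnc3cc(NC(=O)/C=C/c4ccccc4)sc23)c1`: 26200 nM
Compound 2 `O=C(/C=C/c1ccccc1)Nc1cc2c(Nc3ccc(Cl)c(Cl)c3)ncnc2s1`: 7600 nM

Compound 1 has the higher of the two numbers, and its gap to compound 2 lies beyond the scatter. Compound 3 `O=C(/C=C/c1ccccc1)Nc1cc2ncnc(Nc3ccc(Cl)c(Cl)c3)c2s1` keeps the core of compound 1 and changes one group: 3,4-dichlorophenyl in place of 3-ethynylphenyl on a nitrogen on an aromatic ring. Compound 2 also carries 3,4-dichlorophenyl and gives 7600 nM, so a moderate drop beyond the scatter is expected in this assay. The expected step is a 2.6-fold lower number from compound 1 to compound 3 (0.42 log units; beyond the scatter). For compound 3 the estimated value is 10000 nM, with an expected range of 4000 nM to 25000 nM.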

Compound 3, half-maximal inhibitory concentration: 19500 nM
Beside the measured number, compound 3's estimate is 2.0-fold (0.29 log units) below it, within the range that was stated.
By their numbers in this assay, from the lowest: compound 2; then compounds 3 and 1 (each within the scatter of the next).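

In this assay, 3,4-dichlorophenyl in place of 3-ethynylphenyl on a nitrogen on an aromatic ring gives a 1.3-fold lower number from compound 1 to compound 3 (0.13 log units; within the scatter). On the core of compound 1, this assay therefore does not tell these two groups apart. No evidence on the cause of this result is available. Going by these compounds, it remains open whether an unsubstituted phenyl, a pyridine ring or a simple alkyl chain on that nitrogen would move the number beyond the scatter. On these data alone, it also remains open whether an amine or a carboxylic acid on that aromatic ring would do so.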